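The compounds below may be only part of what the source reports. "The series", "measured", "known", "first", "only" and "open" are said of these compounds alone.

Measured so far:
Compound 1 `Nc1ncc(-c2cccc(F)c2)c(-c2ccccc2)n1` gives 63% in an assay on CHO cells for displacement of a labelled ligand from adenosine receptor A1 (Homo sapiens), read by scintillation counting, with a stated time of 1 h, tested at 1 uM; on this read-out higher numbers stand for more inhibition at the one concentration tested (going by the name of the read-out) and lower numbers for less inhibition.
Compound 2 `Nc1ncc(-c2ccccc2)c(-c2ccco2)n1` gives 26% in this assay.
Compound 3 `CC(C)CC(=O)Nc1ncc(-c2cccc(Cl)c2)c(-c2ccccc2)n1` gives 56% in this assay.

Among these three, compound 3 stands second highest. Its nearest neighbour is compound 1, whose value is within the scatter of it, so the two cannot be told apart; compound 2 lies well below both, beyond the scatter. Compound 4 `CC(C)CCNc1ncc(-c2cccc(Cl)c2)c(-c2ccccc2)n1` is not yet measured and differs from compound 3 in one place: isopentyl in place of isobutylcarbonyl on a nitrogen on an aromatic ring. Cut one bond further out, the change reads (isobutylcarbonyl)amino to isopentylamino, so the carbonyl and its acceptor are gone, and the nitrogen now carries a plain chain of the same carbon count. Among the measured compounds shown here, no measured pair shows this kind of change, so its effect in this assay is unknown from the data; the expectation is a small step, not clearly beyond the scatter, in either direction. Compound 4 is therefore estimated at 50%, with a range from 25% to 78%, which means an expected step of a number 6 percentage points lower from compound 3 to compound 4 (within the scatter).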

Compound 4, a percentage reported as inhibition, at one concentration (the size of the read-out at that concentration, not a potency): 39%
Compound 4: the middle estimate sits 11 percentage points above what was measured; the measured number falls inside the stated range.
By their numbers in this assay, from the lowest: compound 2; then compound 4; then compounds 3 and 1 (each within the scatter of the next).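

Within this assay the swap of isobutylcarbonyl for isopentyl on a nitrogen on an aromatic ring gives a number 17 percentage points lower from compound 3 to compound 4 (beyond the scatter) and so shows that the group on this nitrogen affects the reading. Among the compounds shown here, both groups hold five carbons, so this pair tests the loss of the carbonyl, with its one hydrogen-bond acceptor, while the carbon count stays the same, something the earlier compounds could not show. The pair records the drop but does not explain it, and no supporting data bear on the reason.

Going by these compounds, whether the carbonyl alone accounts for the drop stays open, as does whether an acetyl group, a urea or a sulfonyl group on this nitrogen would keep the number up. It is also unknown whether the same swap would give a similar step with a fluorine in place of the chlorine.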